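The source may hold more compounds than are shown below. What is called first, only, known or untested is meant among the compounds shown, and "the series" means these compounds.

Compound 1, `Clc1ccc(OCC2=NCCO2)cc1`: in a functional assay on the whole organism for inhibition, with Rattus norvegicus as the target, read by paw edema, with a stated time of 30 min, at a dose of 40 mg/kg by the oral route (a higher number here means a stronger effect of the compound at the dose given, a lower number a weaker effect), compound 1 gives 48.2%.
Compound 2, `Brc1ccc(OCC2=NCCO2)cc1`: compound 2 gives 48.5%.
Compound 3, `Fc1ccc(OCC2=NCCO2)cc1`: compound 3 gives 30.2%.

Compound 3 stands lowest of the three: the step of a number 18 percentage points lower from compound 1 to compound 3 (beyond the scatter) and the step of a number 18.3 percentage points lower from compound 2 to compound 3 (beyond the scatter) both lie beyond the scatter, whereas a number 0.3 percentage points higher from compound 1 to compound 2 (within the scatter) lies within it. Compound 4, `O=[N+]([O-])c1ccc(OCC2=NCCO2)cc1`, is not yet measured. It differs from compound 3 by nitro in place of fluoro on an aromatic carbon. Within the data shown here, no measured step exchanges a halogen for a nitro group, so the only guide is that replacing fluoro with chloro or bromo on this aromatic carbon raised the read-out by a modest amount. A rise of similar size is therefore expected, a number 14.8 percentage points higher from compound 3 to compound 4 (beyond the scatter). For compound 4 the expected value is 45%, with a likely range from 25% to 65%.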

Compound 4, a percentage reported as inhibition, in the whole organism at one dose (the size of the read-out at that dose, not a potency): 30.4%
Estimate against measurement, compound 4: 14.6 percentage points above; measured number inside the range.
By their numbers in this assay, from the lowest: compounds 3 and 4 (each within the scatter of the next); then compounds 1 and 2 (each within the scatter of the next).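

In this assay, nitro enters with more heavy atoms and more hydrogen-bond acceptors than fluoro, yet the read-out stays level (a number 0.2 percentage points higher from compound 3 to compound 4 (within the scatter)). It also falls short of both larger halogens (a number 18.1 percentage points lower from compound 2 to compound 4 (beyond the scatter); a number 17.8 percentage points lower from compound 1 to compound 4 (beyond the scatter)). The gain seen with chloro and bromo is therefore not shared by every replacement for fluoro at this position, and nothing measured here explains the split into two levels. The compounds shown leave open how a methyl group, an amine or a carboxylic acid would read at this position.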